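Working notes: from compound 3 to compound 4

A few compounds are considered here, and "the series" means these few. Any claim that something is new, unique, unknown or untested is made for them only; others in the source may bear on it.

compound 1 `COC(=O)c1scc(-c2ccc(NC(=O)c3ccc4ccccc4c3)cc2)c1OC` - "not determined" (no result reported)
compound 2 `COC(=O)c1scc(-c2ccc(NC(=O)c3cccc(C(F)(F)F)c3)cc2)c1OC` - "not determined" (no result reported)
compound 3 `COC(=O)c1scc(-c2ccc(NC(=O)c3ccc(OC)nc3)cc2)c1OC` - > 50000 nM
compound 4 `COC(=O)c1scc(-c2ccc(NC(=O)c3ccc(C(F)(F)F)cc3)cc2)c1OC` - not yet measured

For the measured compounds named here, in an ADME assay on HEK293 cells (Homo sapiens) for cytotoxicity, read by MTT assay, with a stated time of 24 h (on this read-out lower numbers stand for stronger inhibition and higher numbers for weaker inhibition), compound 3 stands at > 50000 nM as its only reading, and that reading is a limit of the assay, not a number. Going by the values given here, the series so far holds the limit of > 50000 nM in this assay, at which 1 of the 3 values shown sits, and no single number.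

The change to compound 4 puts 4-(trifluoromethyl)phenyl in place of 6-methoxypyridin-3-yl on a carbonyl carbon and leaves the rest of the structure untouched.

Among the compounds with values here, no pair of measured compounds gives a step size. The expectation therefore rests on compound 3 alone, and no change beyond the scatter is expected in this assay in either direction. The expected move is an at least 1.1-fold lower number from compound 3 to compound 4 (0.04 log units; that floor lies within the scatter) in size. Compound 4 is expected at 45000 nM within a range from 15000 nM to 100000 nM on this estimate, and a report of only a limit is quite possible.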

Compound 4, half-maximal inhibitory concentration: 48300 nM
For compound 4 the middle estimate is 1.1-fold (0.03 log units) below the measured one, and the stated range covers the measured number.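

In this assay compound 4 gives the only single number among the compounds shown, 48300 nM, so this position now has one reading that is not a limit. Compound 3 stands at > 50000 nM, which is a limit and not a number. With 4-(trifluoromethyl)phenyl in place of 6-methoxypyridin-3-yl on a carbonyl carbon, the step reads an at least 1.0-fold lower number from compound 3 to compound 4 (0.01 log units; that floor lies within the scatter), so the change shows no separation between the two groups, and its true size stays open as the step rests on a limit: the limit of > 50000 nM in this assay, at which 1 of the 4 values shown sits.

Compounds 1 and 2 carry no result, so steps involving them cannot be read. As far as these compounds go, whether an amine or a carboxylic acid on this carbonyl carbon, in place of these aromatic groups, would give a clearly lower number remains open.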